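This account rests on a few compounds, and the source may have more. Where it says the series, first, only, none or still open, it means among the compounds named here.

Series notes, step from compound 1 to compound 3.

Among the measured compounds shown here, compound 1 `Fc1ccc2nc(NCCCCN3CCN(c4cccc(Cl)c4Cl)CC3)nc(NCc3ccco3)c2c1` is one of two compounds measured so far. In a functional assay on HCT-116 cells (Homo sapiens) for cytotoxicity, read by MTT assay, with a stated time of 2 days, tested at 10 uM (on this read-out lower numbers stand for less inhibition and higher numbers for more inhibition at the one concentration tested (going by the name of the read-out)), compound 1 gives 97.1%, the lowest of the two numbers. For the measured compounds named here, its nearest neighbour is compound 2 `Cc1cccc(N2CCN(CCCCNc3nc(NCc4ccco4)c4cc(F)ccc4n3)CC2)c1C`, which in this assay gives 97.4%; the only measured step, a number 0.3 percentage points higher from compound 1 to compound 2 (within the scatter), changes the aryl group on the amine nitrogen in a ring and stays within the scatter, so the two values cannot be ordered.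

Compound 3 `Clc1cccc(N2CCN(CCCCNc3nc(NCc4ccco4)c4ccccc4n3)CC2)c1Cl` differs from compound 1 at another site: hydrogen in place of fluoro on an aromatic carbon. Going by the values given here, no measured step touches this position, so the one known step, 2,3-dimethylphenyl in place of 2,3-dichlorophenyl, gives no direct guide to it. What the two numbers do show is that the shared core with either aryl group sits near the top of the read-out in this assay. With no evidence of a sensitive position in the fused ring, the step of a number 3.1 percentage points lower from compound 1 to compound 3 (within the scatter) is expected to stay within the scatter. For compound 3 the estimate in this assay is 94%, with a range from 78% to 99%.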

Compound 3, a percentage reported as inhibition, at one concentration (the size of the read-out at that concentration, not a potency): 94.7%
Compound 3: the middle estimate sits 0.7 percentage points below what was measured; the range from low to high includes it.
By their numbers in this assay, from the lowest: compounds 3, 1 and 2 (each within the scatter of the next).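

In this assay the change at this position, hydrogen in place of fluoro on an aromatic carbon of the fused system, gives a number 2.4 percentage points lower from compound 1 to compound 3 (within the scatter). Among the compounds shown here, this is the first reading at this site, and it shows that compound 3, without the fluoro, still stands near the top of the read-out at the one concentration tested, so the fluoro is not required for a value of this size. Nothing shown accounts for this result or links it to any property of the fluoro or the hydrogen.

Going by these compounds, whether this aromatic carbon also accepts larger or different groups, such as methoxy, an amine or a carboxylic acid, remains open, as does the effect of a longer chain in place of the one joining the two halves of the shared core. On these data alone, with compounds 1, 2 and 3 all close to the top of a read-out taken at a single concentration, it also remains open whether fluoro and hydrogen would separate at lower concentrations.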